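Isoxazole Amidines: From Methylthio to Benzylseleno

The source may hold more compounds than are shown below. What is called first, only, known or untested is meant among the compounds shown, and "the series" means these compounds.

The account concerns two measured compounds and one awaiting measurement in a functional assay on MCF7 cells (Homo sapiens) for cytotoxicity, read by MTT assay, with a stated time of 72 h; a lower number here means a stronger inhibitor of growth, a higher number a weaker inhibitor of growth. Compound 1, `CS/C(=N\C(=O)c1ccno1)NC(=O)c1ccno1`, gives 77800 nM in this assay. Its companion compound 2, `CS/C(=N\C(=O)c1ccco1)NC(=O)c1ccco1`, gives 56100 nM in this assay. Among the two numbers at hand, compound 1 has the higher one, but the gap to compound 2 lies within the scatter, so the two compounds cannot be told apart on these values.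

Compound 3, `O=C(/N=C(/NC(=O)c1ccno1)[Se]Cc1ccccc1)c1ccno1`, differs from compound 1 in one place: a group of 8 heavy atoms (7 carbon, 1 selenium; one six-membered aromatic ring of carbon only) in place of a group of 2 heavy atoms (1 carbon, 1 sulfur; no ring), on a carbon with a double bond to nitrogen. Within the data shown here, no step between measured compounds bears on this change, so any expectation rests only on the two values shown, which sit close together at the weak end of the range.

Among the measured compounds shown here, with no comparable step to lean on, the account expects compound 3 to show a modest step of a 1.9-fold lower number from compound 1 to compound 3 (0.29 log units; within the scatter) towards a lower number in this assay, of a size that may not exceed the scatter. The estimate for compound 3 in this assay is 40000 nM, within 10000 nM to 150000 nM.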

Compound 3, concentration for 50% growth inhibition: 7800 nM
Compound 3: middle estimate off by 5.1-fold (0.71 log units), on the high side; the measured number lies below the stated range.
By their numbers in this assay, from the lowest: compound 3; then compounds 2 and 1 (each within the scatter of the next).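

In this assay, the group of 8 heavy atoms with its selenium and its six-membered aromatic ring, in place of methylsulfanyl on the carbon with a double bond to nitrogen, gives a 10-fold lower number from compound 1 to compound 3 (1.00 log units; beyond the scatter), a step beyond the scatter. Compound 1 and compound 2 both carry methylsulfanyl at this place, so they could say nothing about it; compound 3 shows that the number in this assay responds to a change here. Nothing measured in this account bears on the reason for the step.

The change brings in selenium and the aromatic ring at once, and the compounds shown do not separate the two. As far as these compounds go, a benzylsulfanyl group or a methylselenyl group at this place would bear on that question, and how a longer chain on selenium or an amine here would read remains open.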